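Ethoxy analogue of the aryl beta-amino acid series

A few compounds are considered here, and "the series" means these few. Any claim that something is new, unique, unknown or untested is made for them only; others in the source may bear on it.

Compound 3 `CC(C)(C)Oc1ccc([C@@H](CC(=O)O)NC(=O)[C@@H]2CCCN2S(=O)(=O)c2cc(Cl)cc(Cl)c2)cc1` sits at the low end of the three numbers: in an assay on RPMI-8866 cells for inhibition of integrin alpha-4/beta-1 (Homo sapiens) (a higher number here means a weaker inhibitor, a lower number a stronger inhibitor), compound 3 gives 0.53 nM. Compound 2 `O=C(O)C[C@@H](NC(=O)[C@@H]1CCCN1S(=O)(=O)c1cc(Cl)cc(Cl)c1)c1ccc(O)cc1` gives 0.74 nM and lies within the scatter of it, as shown by a 1.4-fold lower number from compound 2 to compound 3 (0.14 log units; within the scatter). Compound 1 `CC(C)[C@@H](CC(=O)O)NC(=O)[C@@H]1CCCN1S(=O)(=O)c1cc(Cl)cc(Cl)c1` gives 8.9 nM, far away: a 17-fold lower number from compound 1 to compound 3 (1.23 log units; beyond the scatter) and a 12-fold lower number from compound 1 to compound 2 (1.08 log units; beyond the scatter).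

Compound 4 `CCOc1ccc([C@@H](CC(=O)O)NC(=O)[C@@H]2CCCN2S(=O)(=O)c2cc(Cl)cc(Cl)c2)cc1` differs from compound 3 by ethyl in place of tert-butyl on an oxygen on an aromatic ring. The step that bears on this is the one within the scatter from compound 2 to compound 3, where hydrogen and tert-butyl on that same oxygen gave much the same number; ethyl is between these in size. No step beyond the scatter is therefore expected in this assay, a 1.1-fold higher number from compound 3 to compound 4 (0.05 log units; within the scatter). Compound 4 is estimated at 0.6 nM, with a range of 0.25 nM to 1.5 nM.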

Compound 4, half-maximal inhibitory concentration: 0.27 nM
Compound 4: middle estimate off by 2.2-fold (0.35 log units), on the high side, and the stated range covers the measured number.
By their numbers in this assay, from the lowest: compounds 4, 3 and 2 (each within the scatter of the next, the first and the last beyond it); then compound 1.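

On the oxygen on the aromatic ring, ethyl separates from hydrogen (a 2.7-fold lower number from compound 2 to compound 4 (0.44 log units; beyond the scatter)), a separation that tert-butyl did not show, while ethyl and tert-butyl remain together (a 2.0-fold lower number from compound 3 to compound 4 (0.29 log units; within the scatter)). With 4-ethoxyphenyl in place of isopropyl on the saturated chain carbon, the distance from the starting compound widens to the largest step in the series (a 33-fold lower number from compound 1 to compound 4 (1.52 log units; beyond the scatter)). No evidence bears on what lies behind these steps.

Open, as far as these compounds go, is whether a longer chain such as n-butyl on that oxygen keeps the number this low. Also open, from the compounds shown here alone, is how an amine or carboxylic acid at the end of the ethyl chain would read.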